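Working notes: the step from compound 2 to compound 3

The compounds below may be only part of what the source reports. "The series", "measured", "known", "first", "only" and "open" are said of these compounds alone.

In a functional assay on SK-MEL-2 cells (Homo sapiens) for inhibition, read by sulforhodamine B assay, with a stated time of 48 h (a higher number here means a weaker inhibitor, a lower number a stronger inhibitor), compound 2 `O=S(=O)(NCCCNc1nccc(-c2c(-c3cccc(O)c3)nc3sccn23)n1)c1cccc(F)c1` gives 2320 nM and compound 1 `CN1CCCN(CCNc2nccc(-c3c(-c4cccc(O)c4)nc4sccn34)n2)S1(=O)=O` gives 2260 nM. Going by the values given here, these two values lie within the scatter of each other, so compound 2 stands level with the only other measured compound.

Compound 3 `O=S(=O)(NCCNc1nccc(-c2c(-c3cccc(O)c3)nc3sccn23)n1)c1ccc(F)cc1` follows from compound 2 through this change: ((4-fluorophenyl)sulfonyl)amino in place of (((3-fluorophenyl)sulfonyl)amino)methyl on a saturated chain carbon, two bonds along the chain from a nitrogen on an aromatic ring. In words, ((4-fluorophenyl)sulfonyl)amino stands in place of (((3-fluorophenyl)sulfonyl)amino)methyl on a saturated chain carbon, two bonds along the chain from a nitrogen on an aromatic ring.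

Among the compounds with values here, one measured step bears on this, at the same place: a 1.0-fold higher number from compound 1 to compound 2 (0.01 log units; within the scatter). That step replaces a group holding a six-membered non-aromatic ring with one holding a six-membered aromatic ring of carbon only, and it stays within the scatter. Within the data shown here, no measured compound carries the ((4-fluorophenyl)sulfonyl)amino group, so this evidence is thin and the range stays wide.

No change beyond the scatter is expected, and the expected step is a 1.0-fold lower number from compound 2 to compound 3 (0.00 log units; within the scatter). For compound 3 the estimated value is 2300 nM, with an expected range of 1000 nM to 5200 nM.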

Compound 3, half-maximal inhibitory concentration: 4490 nM
Compound 3: the middle estimate sits 2.0-fold (0.29 log units) below what was measured, within the range that was stated.
By their numbers in this assay, from the lowest: compounds 1, 2 and 3 (each within the scatter of the next).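

In this assay there is a 1.9-fold higher number from compound 2 to compound 3 (0.29 log units; within the scatter) when ((4-fluorophenyl)sulfonyl)amino stands in place of (((3-fluorophenyl)sulfonyl)amino)methyl, and there is a 2.0-fold higher number from compound 1 to compound 3 (0.30 log units; within the scatter) when the same group stands in place of the group with the six-membered non-aromatic ring. The position on a saturated chain carbon, two bonds along the chain from a nitrogen on an aromatic ring, now has three different groups on it, and every step among them remains within the scatter, so a second group with a six-membered aromatic ring of carbon only has not separated from the non-aromatic one. This step also alters two things in one move, the fluorine placement named in 3-fluorophenyl and 4-fluorophenyl and the methyl of the leaving group, and its number cannot be divided between them. No measured evidence on any property of these groups bears on the result.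

The compounds shown leave open how the 4-fluorophenyl and 3-fluorophenyl groups compare on an otherwise identical chain. They also leave open whether a primary amine or a carboxylic acid at this position would give a step beyond the scatter.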